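The source may hold more compounds than are shown below. What is called first, only, known or untested is meant among the compounds shown, and "the series" means these compounds.

In a functional assay on MIA PaCa-2 cells (Homo sapiens) for inhibition, read by MTT assay, with a stated time of 3 days (on this read-out higher numbers stand for weaker inhibition and lower numbers for stronger inhibition), compound 1 (`CCOC(=O)[C@H]1CCN(S(=O)(=O)c2ccc(S(=O)(=O)N(CC)CC)cc2)C1`) gives > 10000 nM, which is a limit and not a number. Compound 2 (`CCOC(=O)N1CCC[C@H](S(=O)(=O)c2ccc(S(=O)(=O)N(CC)CC)cc2)C1`) gives > 10000 nM, also a limit. Compound 3 (`CCOC(=O)[C@@H]1CCC[C@H](S(=O)(=O)c2ccc(S(=O)(=O)N(CC)CC)cc2)C1`) gives > 10000 nM, again a limit. Compound 1 therefore has no exact value, and it shares its position with the other two compounds: the limit of > 10000 nM in this assay, at which 3 of the 3 values shown sit. Compound 4 (`CCOC(=O)[C@@H]1CCN(S(=O)(=O)c2ccc(S(=O)(=O)N(CC)CC)cc2)C1`) has the same atoms and bonds as compound 1: the two compounds have the same atoms and bonds and differ only in configuration as drawn: 1 of 1 stereo elements differ; a stereocentre at a saturated ring carbon is drawn S in compound 1 and R in compound 4. With compound 1 known only through (the limit of > 10000 nM in this assay, at which 3 of the 3 values shown sit), no change beyond the scatter is expected, and no direction is favoured. The expected step is a step that the limit leaves unreadable from compound 1 to compound 4. Compound 4 is estimated at 12000 nM, with an expected range from 3000 nM to 30000 nM.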

Compound 4, half-maximal inhibitory concentration: 1500 nM
Compound 4: the middle estimate sits 8.0-fold (0.90 log units) above what was measured; the whole stated range lies above it.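

In this assay, inverting one stereocentre at a saturated ring carbon from the S to the R drawing gives an at least 6.6-fold lower number from compound 1 to compound 4 (0.82 log units; beyond the scatter). For the compounds shown here, compound 4 is the first exact value, where earlier compounds gave no readable difference: the limit of > 10000 nM in this assay, at which 3 of the 4 values shown sit. The step can be assigned to configuration alone, because nothing enters or leaves: the fact that compounds 1 and 4 differ only in the configuration as drawn

Going by these compounds, the full size of the step stays open, with compound 1 known only as a limit. Also open, on these data alone, is whether the R drawing of compound 4 keeps its value with a carboxylic acid or an amide in place of the ethyl ester.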